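A few compounds are considered here, and "the series" means these few. Any claim that something is new, unique, unknown or untested is made for them only; others in the source may bear on it.

Measured compounds:
compound 1 `CCOC(=O)c1c(-c2c(Cl)c3ccccc3oc2=O)nn(-c2cccc(C)c2)c1C(=O)OCC` — 32000 nM in a functional assay on DU-145 cells (Homo sapiens) for cytotoxicity, read by MTT assay, with a stated time of 48 h; a lower number here means a stronger inhibitor, a higher number a weaker inhibitor
compound 2 `CCOC(=O)c1c(-c2cc3ccccc3oc2=O)nn(-c2ccccc2)c1C(=O)OCC` — 57000 nM in this assay
compound 3 `CCOC(=O)c1c(-c2cc3ccccc3oc2=O)nn(-c2cccc(C)c2)c1C(=O)OCC` — 47000 nM in this assay

Compound 3 stands second highest of the three numbers; compound 2 is nearest a 1.2-fold lower number from compound 2 to compound 3 (0.08 log units; within the scatter) and compound 1 furthest a 1.5-fold higher number from compound 1 to compound 3 (0.17 log units; within the scatter), both within scatter. Compound 4 `CCOC(=O)c1c(-c2cc3ccccc3oc2=O)nn(-c2ccc(C)c(C)c2)c1C(=O)OCC` differs from compound 3 by methyl in place of hydrogen on an aromatic carbon. Among the measured compounds shown here, the one measured step of the same kind on this ring, methyl in place of hydrogen, is a 1.2-fold lower number from compound 2 to compound 3 (0.08 log units; within the scatter) and did not leave the scatter. The chloro step from compound 1 does not bear on this change. A second methyl is therefore expected to move this assay by no more than the scatter, in no settled direction. Compound 4 is expected at 45000 nM with a range of 24000 nM to 85000 nM, a step of a 1.0-fold lower number from compound 3 to compound 4 (0.02 log units; within the scatter).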

Compound 4, half-maximal inhibitory concentration: 40000 nM
For compound 4 the middle estimate is 1.1-fold (0.05 log units) above the measured one, within the range that was stated.
By their numbers in this assay, from the lowest: compounds 1, 4, 3 and 2 (each within the scatter of the next).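

In this assay the methyl on the aromatic carbon ortho to a methyl group and para to a large group gives a 1.2-fold lower number from compound 3 to compound 4 (0.07 log units; within the scatter) and so stays inside the scatter at this new place on the ring. Taken together, the full change to 3,4-dimethylphenyl from phenyl gives a 1.4-fold lower number from compound 2 to compound 4 (0.15 log units; within the scatter) and does not leave the scatter either. No measurement on hand accounts for these small steps.

Open, as far as these compounds go, is whether anything other than methyl moves the number at this carbon, such as an amine, a carboxylic acid or a longer alkyl chain. Also open, from the compounds shown here alone, is whether the same ring tolerates such groups when the chloro of compound 1 is present.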